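The compounds below may be only part of what the source reports. "The series", "measured", "known", "first", "only" and "open" are said of these compounds alone.

Measured so far in a functional assay on CCRF-CEM cells (Homo sapiens) for antiproliferative activity, with a stated time of 72 h; a lower number here means a stronger inhibitor, a higher number a weaker inhibitor:
compound 1 `OC[C@H]1O[C@@H](n2cnc3c(NCc4ccc(F)cc4)ncnc32)[C@H](O)[C@@H]1O` gives 1250 nM
compound 2 `COc1cc(CNc2ncnc3c2ncn3[C@@H]2O[C@H](CO)[C@@H](O)[C@H]2O)cc(OC)c1` gives > 166000 nM

Compound 2 stands at the limit of > 166000 nM in this assay, at which 1 of the 2 values shown sits: for compound 2 the assay reports only a limit, > 166000 nM, and not a number. Compound 1 gives 1250 nM. Among the measured compounds shown here, the one measured step is an at least 130-fold higher number from compound 1 to compound 2 (2.12 log units; beyond the scatter). Compound 3 `OC[C@H]1O[C@@H](n2cnc3c(NCc4ccc(F)c(Cl)c4)ncnc32)[C@H](O)[C@@H]1O` is not yet measured; it differs from compound 2 by 3-chloro-4-fluorophenyl in place of 3,5-dimethoxyphenyl on a saturated chain carbon bound to a nitrogen on an aromatic ring. This change removes the group whose introduction produced the large step and installs a ring that shares the fluorine of the 4-fluorophenyl in compound 1, so the step from compound 1 to compound 2 is the one that bears on it, and the reverse direction is expected: a large fall in the number in this assay, an at least 130-fold lower number from compound 2 to compound 3 (2.14 log units; beyond the scatter), is expected. Compound 3 is therefore estimated at 1200 nM, within a range of 300 nM to 6000 nM.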

Compound 3, half-maximal inhibitory concentration: 3400 nM
The estimate for compound 3 lay 2.8-fold (0.45 log units) below the measured number, within the range that was stated.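

Replacing 3,5-dimethoxyphenyl with 3-chloro-4-fluorophenyl on a saturated chain carbon bound to a nitrogen on an aromatic ring gives, in this assay, an at least 48-fold lower number from compound 2 to compound 3 (1.68 log units; beyond the scatter), so the loss seen with compound 2 is not shared by every substituted phenyl at this place. That size is only a floor, and compound 2 is read against a limit and not a number: the limit of > 166000 nM in this assay, at which 1 of the 3 values shown sits. Chloro in place of hydrogen on an aromatic carbon has a much smaller effect, a 2.7-fold higher number from compound 1 to compound 3 (0.43 log units; beyond the scatter), a modest change that still lies beyond the scatter.

The compounds shown cannot separate the effect of having two methoxy groups from that of a single methoxy on the phenyl ring. On these data alone, how a plain phenyl or a ring bearing a carboxylic acid or an amine would behave at this place also remains open.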